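Swapping the aryl group on the ring nitrogen: compound 4

The compounds below may be only part of what the source reports. "The series", "measured", "known", "first", "only" and "open" are said of these compounds alone.

The measured compounds and their values in a functional assay on cells for antagonist activity at C-C chemokine receptor type 1 (Homo sapiens), read by FLIPR and calcium flux; on this read-out lower numbers stand for stronger inhibition and higher numbers for weaker inhibition:
Compound 1 `Cc1c(C(=O)NCc2cccc(C(F)(F)F)c2)cnn1-c1ccc(Cl)c(Cl)c1`: compound 1 gives 500 nM.
Compound 2 `Cc1c(C(=O)NCc2cccc(C(F)(F)F)c2)cnn1-c1ccc(F)cc1`: compound 2 gives 790 nM.
Compound 3 `Cc1c(C(=O)NCc2cccc(C(F)(F)F)c2)cnn1-c1ccccc1Cl`: for compound 3 the assay reports only a limit, > 3000 nM.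

On these data alone, compound 3 thus sits at the weak end of the three, at the limit of this assay described by the limit of > 3000 nM in this assay, at which 1 of the 3 values shown sits, and its true number is unknown beyond that. The steps leading to it are an at least 6.0-fold higher number from compound 1 to compound 3 (0.77 log units; beyond the scatter) and an at least 3.7-fold higher number from compound 2 to compound 3 (0.57 log units; beyond the scatter), both beyond the scatter, while a 1.6-fold higher number from compound 1 to compound 2 (0.20 log units; within the scatter) lies within it.

Compound 4 `Cc1c(C(=O)NCc2cccc(C(F)(F)F)c2)cnn1-c1ccc([N+](=O)[O-])cc1` differs from compound 3 by 4-nitrophenyl in place of 2-chlorophenyl on an aromatic nitrogen. The two measured steps that touch compound 3 both show that the 2-chlorophenyl group goes with a markedly higher number than a 3,4-dichlorophenyl or 4-fluorophenyl group, so removing it is expected to bring the number back down in this assay. As far as these compounds go, the 4-nitrophenyl group of compound 4 is untested. The expected step of an at least 2.5-fold lower number from compound 3 to compound 4 (0.39 log units; beyond the scatter) is placed at a moderate size toward compound 2. Compound 4 is therefore estimated at 1200 nM, with a range from 400 nM to 4000 nM.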

Compound 4, half-maximal inhibitory concentration: 960 nM
Beside the measured number, compound 4's estimate is 1.3-fold (0.10 log units) above it; the measured number falls inside the stated range.
By their numbers in this assay, from the lowest: compounds 1, 2 and 4 (each within the scatter of the next). At a limit, above all of these: compound 3.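

In this assay, the 4-nitrophenyl group on the aromatic nitrogen cannot be told apart from the two other aryl groups that gave a number: a 1.2-fold higher number from compound 2 to compound 4 (0.08 log units; within the scatter) and a 1.9-fold higher number from compound 1 to compound 4 (0.28 log units; within the scatter). Nitro in place of fluoro on this aryl ring, which adds two hydrogen-bond acceptors, therefore leaves the read-out unchanged within the scatter, so compound 3 remains the only one of the four set apart. The step of an at least 3.1-fold lower number from compound 3 to compound 4 (0.49 log units; beyond the scatter) gives only a minimum size, because compound 3 is held at a limit: the limit of > 3000 nM in this assay, at which 1 of the 4 values shown sits.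

Still open, on these data alone, is how an amine or a carboxylic acid on this aryl ring would read in this assay. Also open, as far as these compounds go, is whether any group here can bring the number beyond the scatter of compound 1.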